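Fluoro Removed from the Benzyl Group on the Piperidine

A few compounds are considered here, and "the series" means these few. Any claim that something is new, unique, unknown or untested is made for them only; others in the source may bear on it.

Compound 1, `Cc1cc(C)c(S(=O)(=O)N2CCC(N3CCC(O)CC3)CC2)c(C)c1`, gives 106 nM in a functional assay on DLD-1 cells (Homo sapiens) for antiproliferative activity, read by CellTiter-Glo, with a stated time of 72 h; on this read-out higher numbers stand for weaker inhibition and lower numbers for stronger inhibition.
Compound 2, `Cc1cc(C)c(S(=O)(=O)N2CCC(N3CCC(Cc4ccccc4F)CC3)CC2)c(C)c1`, gives 74 nM in this assay.

Compound 2 holds the lower of the two numbers, yet the step of a 1.4-fold lower number from compound 1 to compound 2 (0.16 log units; within the scatter) stays within the scatter, so the two compounds cannot be ordered against each other. Compound 3, `Cc1cc(C)c(S(=O)(=O)N2CCC(N3CCC(Cc4ccccc4)CC3)CC2)c(C)c1`, has not been measured. It differs from compound 2 by hydrogen in place of fluoro on an aromatic carbon. Among the measured compounds shown here, the only measured step exchanged the whole hydroxy group for 2-fluorobenzyl and did not isolate the fluoro, so no step speaks directly to the present change; the nearest comparison, between compound 1 and compound 2, was itself within the scatter. No step beyond the scatter is therefore expected in this assay for this change. Compound 3 is estimated to give 90 nM, within a range from 40 nM to 200 nM, which is expected to mean a step of a 1.2-fold higher number from compound 2 to compound 3 (0.09 log units; within the scatter).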

Compound 3, half-maximal inhibitory concentration: 3.5 nM
Beside the measured number, compound 3's estimate is 26-fold (1.41 log units) above it; measured number below the stated range.
By their numbers in this assay, from the lowest: compound 3; then compounds 2 and 1 (each within the scatter of the next).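

In this assay, taking the single fluorine off the 2-fluorobenzyl group gives a 21-fold lower number from compound 2 to compound 3 (1.33 log units; beyond the scatter), so this one atom, ortho to a large group on the aromatic ring, matters far more than the earlier exchange of hydroxy for 2-fluorobenzyl could show. The plain benzyl group also separates clearly from hydroxy, with a 30-fold lower number from compound 1 to compound 3 (1.48 log units; beyond the scatter), whereas the 2-fluorobenzyl group did not, so among these compounds the benzyl exchange shows a large step only without the fluoro. No measurement at hand accounts for this difference.

The compounds shown leave open whether a chlorine, a methyl or a methoxy on this same aromatic carbon would read like the fluoro or like the hydrogen. They also leave open how an amine or a carboxylic acid on the phenyl ring would read.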